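Aryl urea series: methyl for fluoro on the aniline ring

The source may hold more compounds than are shown below. What is called first, only, known or untested is meant among the compounds shown, and "the series" means these compounds.

Measured compounds:
Compound 1 `Cc1ccc(NC(=O)N[C@@H](C)c2ccccc2)cc1` gives 100% in an ADME assay on the whole organism with Oryza sativa as the target, tested at 10 uM; on this read-out higher numbers stand for a weaker effect at the one concentration tested and lower numbers for a stronger effect.
Compound 2 `C[C@H](NC(=O)Nc1ccc(F)cc1)c1ccccc1` gives 85% in this assay.
Compound 3 `C[C@@H](NC(=O)Nc1ccc(F)cc1F)c1ccccc1` gives 93% in this assay.

For the measured compounds named here, the one counted step is a number 15 percentage points higher from compound 2 to compound 1 (beyond the scatter), the change being (methyl in place of fluoro on an aromatic carbon). The values of compound 3 and compound 1 lie within the scatter of each other, as do those of compound 3 and compound 2, so no order among them is claimed. The difference between the cores of compound 3 and compound 2 is not broken down here.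

Compound 4 `Cc1ccc(NC(=O)N[C@H](C)c2ccccc2)c(F)c1` is not yet measured. It differs from compound 3 by methyl in place of fluoro on an aromatic carbon. The place is the same kind of place as in the step from compound 2 to compound 1, but not the same: here the changed carbon is meta to a fluoro group (1 heavy atom) besides being para to a large group.

In this assay, going by the values given here, the step from compound 3 to compound 4 is expected to be a number 6 percentage points higher from compound 3 to compound 4 (within the scatter), smaller than the one from compound 2 to compound 1, because compound 3 already gives 93% and little room remains upward. Compound 4 is thus estimated at 99%, with a range from 88% to 106%.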

Compound 4, a percentage reported as activity, at one concentration (the size of the read-out at that concentration, not a potency): 99%
Estimate against measurement, compound 4: no gap at the digits printed; measured number inside the range.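

In this assay, methyl in place of fluoro on an aromatic carbon now gives a number 6 percentage points higher from compound 3 to compound 4 (within the scatter), and the comparison with the earlier step on the other core finds no separable difference in size: the same change on two cores in this assay, a number 15 percentage points higher (beyond the scatter) from compound 2 to compound 1 and a number 6 percentage points higher (within the scatter) from compound 3 to compound 4, 9 percentage points apart, within the scatter of two such steps The two cores are therefore compatible with a shared effect of this change, but that agreement does not establish a shared effect, as the new step alone lies within the scatter. Two pairs also say nothing about how the change behaves on any other core, and they do not show whether the fluoro group present in compound 4 alters the step.

The compounds shown leave open how other groups at the same aromatic carbon would read in this assay, for example chloro, methoxy, trifluoromethyl or a nitrile. Also open, going by these compounds, is whether the same step holds when the urea is replaced by an amide or when the methyl on the chain carbon gives way to a longer chain.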